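Benzyl-substituted core series: amine change at compound 4

The compounds below may be only part of what the source reports. "The series", "measured", "known", "first", "only" and "open" are said of these compounds alone.

Measured so far:
- compound 1, `c1ccc(Cn2nnc3c(NC4CC4)nc(-c4ccccc4)nc32)cc1`: 11.3 nM
- compound 2, `Fc1ccccc1Cn1nnc2c(NC3CC3)nc(-c3ccccc3)nc21`: 15 nM
- compound 3, `FC(F)(F)c1ccccc1Cn1nnc2c(NC3CC3)nc(-c3ccccc3)nc21`: 7.8 nM

In an assay on Cerebral cortex for displacement of a labelled ligand from adenosine receptor A1 (Bos taurus) (on this read-out higher numbers stand for weaker inhibition and lower numbers for stronger inhibition), compound 2 gives the highest of the three numbers, but its steps to both neighbours stay within the scatter: a 1.3-fold higher number from compound 1 to compound 2 (0.12 log units; within the scatter) and a 1.9-fold lower number from compound 2 to compound 3 (0.28 log units; within the scatter). The third measured step, a 1.4-fold lower number from compound 1 to compound 3 (0.16 log units; within the scatter), is likewise within the scatter, so the three benzyl-ring variants are indistinguishable on this read-out.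

Compound 4, `CC(O)CNc1nc(-c2ccccc2)nc2c1nnn2Cc1ccccc1F`, is not yet measured. It differs from compound 2 at the amine, not at the benzyl ring: 2-hydroxypropyl in place of cyclopropyl on a nitrogen on an aromatic ring. Among the measured compounds shown here, no measured step touches this nitrogen; all three measured steps concern substituents on the benzyl ring and were all within the scatter. For the measured compounds named here, there is therefore no direct precedent in this set for the amine change, and the expectation rests on the series value near compound 2 with a wide range.

For compound 4 the estimate in this assay is 30 nM, range 8 nM to 120 nM, which means an expected step of a 2.0-fold higher number from compound 2 to compound 4 (0.30 log units; within the scatter), possibly beyond the scatter toward a higher number.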

Compound 4, inhibition constant: 4.8 nM
Estimate against measurement, compound 4: 6.3-fold (0.80 log units) above; the measured number lies below the stated range.
By their numbers in this assay, from the lowest: compounds 4, 3, 1 and 2 (each within the scatter of the next, the first and the last beyond it).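

Among the compounds shown here, the amine is the first position where a single change moves this assay beyond the scatter: cyclopropylamino to (2-hydroxypropyl)amino gives a 3.1-fold lower number from compound 2 to compound 4 (0.49 log units; beyond the scatter), whereas all three benzyl-ring steps stayed within it. The three-membered ring on this nitrogen is therefore not needed for stronger inhibition here, since the open 2-hydroxypropyl chain, which brings a hydrogen-bond donor and acceptor, gives the lower number. This single step cannot separate the loss of the ring from the entry of the hydroxyl, and no supporting measurement bears on the result.

On these data alone, whether the hydroxyl matters remains open; a plain propyl chain, or an amine in place of the hydroxyl, would address that. Also open, as far as these compounds go, is whether the same amine change carries over to the benzyl group of compound 1 or the trifluoromethyl-bearing benzyl group of compound 3.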